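Amino in place of chloro on the core of compound 3

A few compounds are considered here, and "the series" means these few. Any claim that something is new, unique, unknown or untested is made for them only; others in the source may bear on it.

Compound 1, `CC(=O)OC(C)n1cnc2c(Cl)nc(N)nc21`, gives > 500000 nM in a functional assay (Homo sapiens) for inhibition; a higher number here means a weaker inhibitor, a lower number a stronger inhibitor; compound 1 sits at a limit of the assay, not at a number.
Compound 2, `CC(=O)OC(C)n1cnc2c(Cl)nc(I)nc21`, gives 14500 nM in this assay.
Compound 3, `CC(O)n1cnc2c(Cl)nc(I)nc21`, gives > 500000 nM in this assay; compound 3 likewise sits at a limit, not at a number.

Compound 3 therefore stands at the limit of this assay, (the limit of > 500000 nM in this assay, at which 2 of the 3 values shown sit). Two steps between measured compounds are known. The first is an at least 34-fold lower number from compound 1 to compound 2 (1.53 log units; beyond the scatter). The second is an at least 34-fold higher number from compound 2 to compound 3 (1.53 log units; beyond the scatter). Compound 4, `CC(O)n1cnc2c(N)nc(I)nc21`, differs from compound 3 by amino in place of chloro on an aromatic carbon. Neither measured step concerns this exchange: the first alters a different substituent on the same ring, and the second removes the acetyl group, which compound 4 does not carry either, since it keeps the free hydroxyl of compound 3. Within the data shown here, no measured step thus speaks to the size or direction of the change in this assay. Since compound 3 already sits at the limit, compound 4 is expected to stay at or near that limit, with a step that the limit leaves unreadable from compound 3 to compound 4 as the expected step. The estimate for compound 4 is 600000 nM, within a range from 150000 nM to 3000000 nM.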

Compound 4, half-maximal inhibitory concentration: > 500000 nM
Compound 4: no number, only a limit; the forecaster's own chance of this, stated with the estimate: 85%; the middle value lies beyond the limit too.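

In this assay compound 4 gives > 500000 nM, which is a limit and not a number. Compound 3 sits at a limit as well, so no step can be read between compound 3 and compound 4. The compounds shown leave open whether amino in place of chloro on an aromatic carbon changes inhibition at all, and in which direction.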